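The source may report more compounds than this note shows. Statements on the series, on what has been measured and on what is new or still open speak of the compounds shown alone.

Compound 2 `Cc1ccccc1N1CCN(CCCCNC(=O)c2ccc3ccccc3c2)CC1` is measured in an assay on isolated protein for displacement of a labelled ligand from Alpha-1A adrenergic receptor (Homo sapiens) (a lower number here means a stronger inhibitor, a higher number a weaker inhibitor), at 29.9 nM. Compound 1 `O=C(NCCCCN1CCN(c2ccccc2Cl)CC1)c1ccc2ccccc2c1` gives 29.9 nM, and the step of no change at the digits printed from compound 1 to compound 2 (within the scatter) stays within the scatter, so the two stand level, together the lowest of the three numbers. Compound 3 `CCOC(=O)Nc1cccc(N2CCN(CCCCNC(=O)c3ccc4ccccc4c3)CC2)c1` gives 1030 nM, the highest of the three. Compound 4 `O=C(NCCCCN1CCN(c2cccc(Cl)c2)CC1)c1ccc2ccccc2c1` has not been measured; it carries 3-chlorophenyl in place of 2-methylphenyl on an amine nitrogen in a ring. Among the measured compounds shown here, no measured step moves a group on that phenyl ring in this way, so the only guide is that compound 1 and compound 2 sit together while compound 3 lies far higher. The step of a 2.7-fold higher number from compound 2 to compound 4 (0.43 log units; beyond the scatter) is therefore expected to be modest, probably toward a higher number. Compound 4 is estimated at 80 nM, within 25 nM to 300 nM.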

Compound 4, inhibition constant: 50.2 nM
Compound 4: middle estimate off by 1.6-fold (0.20 log units), on the high side; the range from low to high includes it.
By their numbers in this assay, from the lowest: compounds 1, 2 and 4 (each within the scatter of the next); then compound 3.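

In this assay, the 3-chlorophenyl group stands level with both earlier groups, as a 1.7-fold higher number from compound 2 to compound 4 (0.23 log units; within the scatter) and a 1.7-fold higher number from compound 1 to compound 4 (0.23 log units; within the scatter) show, so these three phenyl groups on the ring amine nitrogen cannot be told apart here. Chloro in place of (ethoxycarbonyl)amino gives a 21-fold lower number from compound 3 to compound 4 (1.31 log units; beyond the scatter), so the high number of compound 3 goes with that group and not simply with the phenyl ring carrying a group at that carbon. Nothing available explains these results.

Still open, as far as these compounds go, is whether methoxy, hydroxyl or an amine on this phenyl ring would keep the number this low.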